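A Single Aryl Swap, Measured Once and Expected Again

This account rests on a few compounds, and the source may have more. Where it says the series, first, only, none or still open, it means among the compounds named here.

Compound 1 `Cn1ncc2c(NC(=O)NCc3cc(C(F)(F)F)nn3-c3cccc(C(F)(F)F)c3)cccc21`: 1.4 nM
Compound 2 `Cn1ncc2c(NC(=O)NCc3cc(C(F)(F)F)nn3-c3ccc(F)cc3)cccc21`: 8.4 nM
Compound 3 `CC(C)(C)c1cc(CNC(=O)Nc2cccc3[nH]ncc23)n(-c2cccc(C(F)(F)F)c2)n1`: 0.3 nM

Of the compounds shown here, three have been measured in an assay on CHO-K1 cells for antagonist activity at transient receptor potential cation channel subfamily V member 1 (Homo sapiens), read by FLIPR and calcium flux, with a stated time of 6 min; a lower number here means a stronger inhibitor, a higher number a weaker inhibitor. Compound 1 gives 1.4 nM in this assay, compound 2 gives 8.4 nM, and compound 3 gives 0.3 nM, the lowest of the three numbers. The change from compound 1 to compound 2 is 4-fluorophenyl in place of 3-(trifluoromethyl)phenyl on an aromatic nitrogen, and it produced a 6.0-fold higher number from compound 1 to compound 2 (0.78 log units; beyond the scatter). How the core of compound 3 differs from the core of compound 1 is not broken down here.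

Compound 4 `CC(C)(C)c1cc(CNC(=O)Nc2cccc3[nH]ncc23)n(-c2ccc(F)cc2)n1` has not yet been measured. It differs from compound 3 by 4-fluorophenyl in place of 3-(trifluoromethyl)phenyl on an aromatic nitrogen, the same kind of change as that from compound 1 to compound 2, but around the place the surroundings are not identical: in compound 3 the ring atom two ring bonds away bears a tert-butyl group, whereas in compound 1 it bears a trifluoromethyl group. Because the earlier change gave a 6.0-fold higher number from compound 1 to compound 2 (0.78 log units; beyond the scatter), a step of similar size is expected here, namely a 6.0-fold higher number from compound 3 to compound 4 (0.78 log units; beyond the scatter). Compound 4 is therefore estimated at 1.8 nM in this assay, with a likely range from 0.6 nM to 5 nM.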

Compound 4, inhibition constant: 2.2 nM
Beside the measured number, compound 4's estimate is 1.2-fold (0.09 log units) below it, within the range that was stated.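

In this assay, putting 4-fluorophenyl in place of 3-(trifluoromethyl)phenyl on the aromatic nitrogen gave a 7.3-fold higher number from compound 3 to compound 4 (0.87 log units; beyond the scatter), so the loss seen on the first core appeared again on the second. Set beside the earlier step, the change shows no difference in size between the two cores: the same change on two cores in this assay, a 6.0-fold higher number (0.78 log units; beyond the scatter) from compound 1 to compound 2 and a 7.3-fold higher number (0.87 log units; beyond the scatter) from compound 3 to compound 4, 1.2-fold (0.09 log units) apart, within the scatter of two such steps. This shows that the step carried over between these two cores, even with a tert-butyl group rather than a trifluoromethyl group on the ring atom two ring bonds away, but two pairs do not show that it would hold on any other core, nor do they explain why the step has this size.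

The compounds shown carry only these two aryl groups on the nitrogen and only tert-butyl or trifluoromethyl at that ring atom. From the compounds shown here alone, whether the step would keep its size with an isopropyl group or an amine at that ring atom, or how a chlorine atom on the aryl ring would compare, remains open.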